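The source may report more compounds than this note shows. Statements on the series, on what has been measured and on what is new or still open speak of the compounds shown alone.

Measured compounds:
compound 1 `COc1cc(/C=C/C(=O)C2=C(/C=C/c3ccc(O)c(OC)c3)NC(=O)NC2c2ccccc2O)ccc1O`: 33.6%
compound 2 `COc1cc(/C=C/C(=O)C2=C(/C=C/c3ccc(O)c(OC)c3)NC(=O)NC2c2ccc(O)cc2)ccc1O`: 25%

In a functional assay, with a stated time of 20 min, tested at 2 uM (on this read-out higher numbers stand for a stronger effect at the one concentration tested and lower numbers for a weaker effect), compound 1 gives 33.6%, and the step of a number 8.6 percentage points lower from compound 1 to compound 2 (within the scatter) keeps compound 2 within the scatter of it. Compound 3 `COc1cc(/C=C/C(=O)C2=C(/C=C/c3ccc(O)c(OC)c3)NC(=O)NC2c2ccccc2Cl)ccc1O` is not yet measured. It differs from compound 1 by chloro in place of hydroxy on an aromatic carbon, read one bond further out as 2-hydroxyphenyl to 2-chlorophenyl. Going by the values given here, no measured step swaps hydroxy for chloro; the only step at hand, a number 8.6 percentage points lower from compound 1 to compound 2 (within the scatter), moves the hydroxy on that phenyl and stays within the scatter. A step within the scatter is therefore expected for a number 3.6 percentage points lower from compound 1 to compound 3 (within the scatter). Compound 3 is estimated to give 30%, between 14% and 46%.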

Compound 3, a percentage reported as activity, at one concentration (the size of the read-out at that concentration, not a potency): 20.2%
Compound 3: the middle estimate sits 9.8 percentage points above what was measured, and the stated range covers the measured number.
By their numbers in this assay, from the lowest: compounds 3, 2 and 1 (each within the scatter of the next, the first and the last beyond it).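

In this assay, going by these compounds alone, chloro in place of hydroxy on this aromatic carbon gives a number 13.4 percentage points lower from compound 1 to compound 3 (beyond the scatter), the only step so far beyond the scatter, so exchanging the group here registers where moving the hydroxy on that phenyl did not. With a number 4.8 percentage points lower from compound 2 to compound 3 (within the scatter), compound 3 cannot be told apart from compound 2. Nothing available offers a reason for either step.

As far as these compounds go, whether the drop follows from losing the hydroxy or from gaining chloro remains open. A methoxy or an amine on the same carbon could separate the two readings.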